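A few compounds are considered here, and "the series" means these few. Any claim that something is new, unique, unknown or untested is made for them only; others in the source may bear on it.

In a functional assay on T98G cells (Homo sapiens) for inhibition, read by MTT assay, with a stated time of 72 h (a higher number here means a weaker inhibitor, a lower number a stronger inhibitor), compound 1 (`CC1(C)CC(NC(=S)Nc2ccc([N+](=O)[O-])cc2)c2cc(Br)ccc2O1`) gives 5000 nM and compound 2 (`CC1(C)CC(NC(=S)Nc2ccc([N+](=O)[O-])cc2)c2cc(Cl)ccc2O1`) gives 4000 nM, so the two values sit within the scatter of each other. Among the compounds with values here, the only measured step, a 1.3-fold lower number from compound 1 to compound 2 (0.10 log units; within the scatter), is chloro in place of bromo on an aromatic carbon, and it stays within the scatter. Compound 3 (`CC1(C)CC(NC(=S)Nc2ccc(Cl)cc2)c2cc(Br)ccc2O1`) keeps the bromo of compound 1 and changes elsewhere: chloro in place of nitro on an aromatic carbon, para to a large group. Within the data shown here, no measured step covers this kind of change, so the one available step bears on it only weakly and gives no direction. No shift beyond the scatter is therefore expected, though with low confidence, and the estimated step is no change at the digits printed from compound 1 to compound 3 (within the scatter). For compound 3 the estimated value is 5000 nM, with an expected range from 1500 nM to 15000 nM.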

Compound 3, half-maximal inhibitory concentration: 22000 nM
Compound 3: the middle estimate sits 4.4-fold (0.64 log units) below what was measured; measured number above the stated range.
By their numbers in this assay, from the lowest: compounds 2 and 1 (each within the scatter of the next); then compound 3.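

In this assay, within the data shown here, chloro in place of nitro on the aromatic carbon para to a large group gives a 4.4-fold higher number from compound 1 to compound 3 (0.64 log units; beyond the scatter), the only step so far that lies beyond the scatter. The other step, a 1.3-fold lower number from compound 1 to compound 2 (0.10 log units; within the scatter), is a change at a different place on the core and stays within the scatter, so this position registers a substituent change where the bromo-to-chloro swap did not. With the bromo kept in place, nitro therefore gives the lower number of the two groups here, but no measurement at hand accounts for the difference.

On these data alone, whether the same step holds with the chloro of compound 2 in place of the bromo remains open. As far as these compounds go, it is also open where groups such as nitrile, trifluoromethyl, methoxy or an amine would fall at this position relative to nitro and chloro.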